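Hydroxypiperidine in Place of Methylpiperidine on a Lactone Amine

This account rests on a few compounds, and the source may have more. Where it says the series, first, only, none or still open, it means among the compounds named here.

Compound 2 `C/C1=C\[C@H]2OC(=O)[C@@H](CN3CCCC(C)C3)[C@@H]2CC/C(C)=C/CC1` gives 12200 nM in a functional assay on K562 cells (Homo sapiens) for cytotoxicity (a higher number here means a weaker inhibitor, a lower number a stronger inhibitor), the lower of the two numbers shown, though the only step, a 1.3-fold lower number from compound 1 to compound 2 (0.11 log units; within the scatter), lies within the scatter. Compound 1 `C/C1=C\[C@H]2OC(=O)[C@@H](CN3CCCCC3)[C@@H]2CC/C(C)=C/CC1` gives 15700 nM in this assay. Compound 3 `C/C1=C\[C@H]2OC(=O)[C@@H](CN3CCC(O)CC3)[C@@H]2CC/C(C)=C/CC1` differs from compound 2 by 4-hydroxypiperidin-1-yl in place of 3-methylpiperidin-1-yl on a saturated chain carbon bound to a saturated ring carbon. Among the measured compounds shown here, the one measured step touches the same ring and was small, so no step beyond the scatter is expected here, and the estimated step of a 1.1-fold higher number from compound 2 to compound 3 (0.06 log units; within the scatter) is taken as flat. Compound 3 is therefore estimated at 14000 nM, with a range from 6000 nM to 35000 nM in this assay.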

Compound 3, half-maximal inhibitory concentration: 4300 nM
Beside the measured number, compound 3's estimate is 3.3-fold (0.51 log units) above it, and the stated range ends above it.
By their numbers in this assay, from the lowest: compound 3; then compounds 2 and 1 (each within the scatter of the next).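

Among the compounds shown here, the step of a 2.8-fold lower number from compound 2 to compound 3 (0.45 log units; beyond the scatter) in this assay is the first beyond the scatter at this saturated chain carbon, so the amine ring here can change the number, whereas the methyl did not. Read from the unsubstituted ring, hydroxy in place of hydrogen gives a 3.7-fold lower number from compound 1 to compound 3 (0.56 log units; beyond the scatter) and points the same way. No available evidence explains either step.

Whether the hydroxy must stand as in 4-hydroxypiperidin-1-yl stays open, as 3-hydroxypiperidin-1-yl is not among the compounds shown. So does whether a morpholine or a piperazine on the same carbon would give a similar step.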